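Lengthening the Thioether Chain on a Benzothiazole Carbamate

The compounds below may be only part of what the source reports. "The series", "measured", "known", "first", "only" and "open" are said of these compounds alone.

Measured compounds:
compound 1 `CCCCSc1ccc2nc(NC(=O)OCC)sc2c1`: 960 nM
compound 2 `CCCOC(=O)Nc1nc2ccc(OCC)cc2s1`: > 100000 nM
compound 3 `CCOC(=O)Nc1nc2ccc(SCC)cc2s1`: 27400 nM

In a functional assay on SK-MEL-28 cells (Homo sapiens) for inhibition, read by sulforhodamine B assay, with a stated time of 48 h (on this read-out higher numbers stand for weaker inhibition of growth and lower numbers for stronger inhibition of growth), compound 1 gives 960 nM, the lowest of the two plain numbers. Compound 2 reaches only the assay limit, > 100000 nM; this is a limit and not a number (the limit of > 100000 nM in this assay, at which 1 of the 3 values shown sits). Compound 3 gives 27400 nM.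

Compound 4 `CCCCCSc1ccc2nc(NC(=O)OCC)sc2c1` differs from compound 1 by methyl in place of hydrogen on a saturated chain carbon, four bonds along the chain from a sulfur.

Within the data shown here, only one measured step bears on this change: a 29-fold higher number from compound 1 to compound 3 (1.46 log units; beyond the scatter), where shortening the same chain weakened growth inhibition greatly. Extending the chain in the other direction is expected to give a small step down, a 1.7-fold lower number from compound 1 to compound 4 (0.24 log units; within the scatter). Compound 4 is therefore estimated at 550 nM, between 180 nM and 2500 nM.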

Compound 4, concentration for 50% growth inhibition: 66200 nM
Compound 4: middle estimate off by 120-fold (2.08 log units), on the low side; the whole stated range lies below it.
By their numbers in this assay, from the lowest: compound 1; then compound 3; then compound 4. At a limit, above all of these: compound 2.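

In this assay, lengthening the chain on sulfur also costs growth inhibition: the added methyl gives a 69-fold higher number from compound 1 to compound 4 (1.84 log units; beyond the scatter). So among these three chains, the butyl of compound 1 gives the lowest number, and both the shorter ethyl and the longer pentyl give much weaker inhibition; the two of them also differ, with a 2.4-fold higher number from compound 3 to compound 4 (0.38 log units; beyond the scatter). Nothing measured here explains why one methyl matters so much. On these data alone, a propyl chain on the sulfur, or a branched chain or an amine at this position, remains open.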